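The source may report more compounds than this note shows. Statements on the series, on what has been measured and on what is new or still open speak of the compounds shown alone.

Of the compounds shown here, two of a shared core have been tested so far. Compound 1 `N#Cc1c(/N=C/c2ccc3ncccc3c2)sc2c1CCCCC2` and compound 2 `N#Cc1c(/N=C/c2cc3ccccc3[nH]2)sc2c1CCCCC2` differ in the aromatic group carried on the imine. In an ADME assay on cells (Peritoneal macrophage cell, Mus musculus, strain Swiss) for cytotoxicity, read by MTT assay, with a stated time of 24 h (a lower number here means that less compound is tolerated, a higher number that more compound is tolerated), compound 1 gives 438000 nM. In this assay compound 2 gives 49100 nM, the lower of the two numbers, and the gap to compound 1 lies beyond the scatter, so compound 2 is the less well tolerated of the pair.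

Compound 3 `N#Cc1c(/N=C/c2cc3cc(Br)ccc3[nH]2)sc2c1CCCCC2` has not yet been measured. It differs from compound 2 in one place: bromo in place of hydrogen on an aromatic carbon.

Among the compounds with values here, no measured pair shows what such a change does here, so the expectation rests on compound 2 alone. The step from compound 2 to compound 3 in this assay is expected to be small, at most a slight move toward a lower number, and possibly none beyond the scatter, as a 1.4-fold lower number from compound 2 to compound 3 (0.15 log units; within the scatter). For compound 3 in this assay the estimated value is 35000 nM, within a range from 12000 nM to 110000 nM.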

Compound 3, half-maximal cytotoxic concentration: 32000 nM
Estimate against measurement, compound 3: 1.1-fold (0.04 log units) above; low and high end bracket the measured number.
By their numbers in this assay, from the lowest: compounds 3 and 2 (each within the scatter of the next); then compound 1.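

This first measured step of its kind, a 1.5-fold lower number from compound 2 to compound 3 (0.19 log units; within the scatter), shows that in this assay bromo in place of hydrogen at this place, on the six-membered aromatic ring of carbon only, does not separate compound 3 from compound 2 by more than the scatter. The aromatic carbon therefore carries this one added heavy atom with no measurable shift in how much compound the macrophages tolerate. No measurement at hand offers an explanation for this outcome.

On these data alone, whether this holds only for bromo or also for other groups at this place, such as a methoxy group, an amine or a carboxylic acid, remains open. Also open, as far as these compounds go, is whether bromo on another carbon of that ring, or on the aromatic group of compound 1, would give the same result.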